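Extending the piperidine amide in a thyroid receptor series

The source may report more compounds than this note shows. Statements on the series, on what has been measured and on what is new or still open speak of the compounds shown alone.

Compound 1 `COc1cc(C(=O)N2CCCC2)cc2nc(NCc3cccc(Cl)c3)oc12`: 180 nM
Compound 2 `COc1cc(C(=O)N2CC[C@@H](O)[C@H](C)C2)cc2nc(NCc3cccc(Cl)c3)oc12`: 10 nM

Both compounds were tested in an assay on isolated protein for inhibition of thyroid hormone receptor beta (Homo sapiens), read by fluorescence, with a stated time of 30 min; a higher number here means a weaker inhibitor, a lower number a stronger inhibitor. Within the data shown here, compound 2 stands at the lowest of the two numbers; compound 1 is its only neighbour. Among the measured compounds shown here, the single measured step is an 18-fold lower number from compound 1 to compound 2 (1.26 log units; beyond the scatter), in which 4-hydroxy-3-methylpiperidin-1-yl took the place of pyrrolidin-1-yl on a carbonyl carbon. That step shows the amide substituent on this shared core can move the read-out strongly.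

Compound 3 `COc1cc(C(=O)N2CC(C)C(O)CC2CCO)cc2nc(NCc3cccc(Cl)c3)oc12` is not yet measured. It differs from compound 2 by 4-hydroxy-2-(2-hydroxyethyl)-5-methylpiperidin-1-yl in place of 4-hydroxy-3-methylpiperidin-1-yl on a carbonyl carbon. For the measured compounds named here, this change touches the same region as the measured step, but it adds a new side chain rather than changing ring size, and no measured pair tells how such an addition behaves here; the stereocentres of compound 3 are also undefined. The large step seen in this assay therefore gives only a loose guide. A small shift, most likely toward a somewhat higher number, is expected. The expected step is a 2.5-fold higher number from compound 2 to compound 3 (0.40 log units; beyond the scatter). Compound 3 is therefore estimated at 25 nM, with a range from 6 nM to 120 nM.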

Compound 3, half-maximal inhibitory concentration: 0.27 nM
Beside the measured number, compound 3's estimate is 93-fold (1.97 log units) above it; the whole stated range lies above it.
By their numbers in this assay, from the lowest: compound 3; then compound 2; then compound 1.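

Adding to the ring did not cost activity. In this assay, the 2-(2-hydroxyethyl) side chain on the piperidine, with 4-hydroxy-2-(2-hydroxyethyl)-5-methylpiperidin-1-yl entering on the carbonyl carbon, gives a 37-fold lower number from compound 2 to compound 3 (1.57 log units; beyond the scatter), so the read-out at this position had not levelled off after the first change. Measured from the pyrrolidin-1-yl amide, the total change is a 670-fold lower number from compound 1 to compound 3 (2.82 log units; beyond the scatter), which shows that the group on this one carbonyl carbon alone can carry a very wide span of inhibition on the shared core. Nothing available here accounts for the gain.

The compounds shown leave open whether the hydroxyl of the 2-hydroxyethyl chain matters or the carbon chain alone is enough, and how an ethyl chain, a longer chain or a 2-aminoethyl chain would read in its place. On these data alone, the stereocentres of compound 3 are undefined, so it also remains open how the measured number would divide among its individual stereoisomers, and whether any one of them would give a lower number still.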